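Solubility notes: tert-butyl urea analogue of the sulfonamide series

The source may report more compounds than this note shows. Statements on the series, on what has been measured and on what is new or still open speak of the compounds shown alone.

Compound 1 `O=C(Cn1ccnc1)N1CCC(NS(=O)(=O)c2cc(S(=O)(=O)c3ccccc3)ccc2C(F)(F)F)CC1` gives 100000 nM in a physicochemical assay for solubility (a higher number here means a more soluble compound, a lower number a less soluble compound), the highest of the two numbers recorded so far. Compound 2 `CC(C)(C)C(=O)N1CCC[C@H]1C(=O)N1CCC(NS(=O)(=O)c2cc(S(=O)(=O)c3ccccc3)ccc2C(F)(F)F)CC1` gives 50000 nM in this assay, and the step of a 2.0-fold lower number from compound 1 to compound 2 (0.30 log units; within the scatter) lies within the scatter. Compound 3 `CC(C)(C)NC(=O)N1CCC[C@H]1C(=O)N1CCC(NS(=O)(=O)c2cc(S(=O)(=O)c3ccccc3)ccc2C(F)(F)F)CC1` is not yet measured in this assay; it differs from compound 1 by 1-((tert-butyl)carbamoyl)pyrrolidin-2-yl in place of (1H-imidazol-1-yl)methyl on a carbonyl carbon. Within the data shown here, the only step bearing on this change is a 2.0-fold lower number from compound 1 to compound 2 (0.30 log units; within the scatter), which shares the pyrrolidin-2-yl part of the entering group and was small. No step beyond the scatter is therefore expected in this assay. Compound 3 is estimated at 60000 nM, with a range from 25000 nM to 150000 nM. The expected step is a 1.7-fold lower number from compound 1 to compound 3 (0.22 log units; within the scatter).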

Compound 3, solubility: 50000 nM
For compound 3 the middle estimate is 1.2-fold (0.08 log units) above the measured one; the measured number falls inside the stated range.
By their numbers in this assay, from the lowest: compounds 2, 3 and 1 (each within the scatter of the next).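

In this assay, the 1-((tert-butyl)carbamoyl)pyrrolidin-2-yl group in place of (1H-imidazol-1-yl)methyl on a carbonyl carbon gives a 2.0-fold lower number from compound 1 to compound 3 (0.30 log units; within the scatter). The further exchange of tert-butyl for (tert-butyl)amino on a carbonyl carbon gives no change at the digits printed from compound 2 to compound 3 (within the scatter), so this single change, which adds a hydrogen-bond donor, leaves the reading within the scatter. No available evidence bears on the reason for either step.

Going by these compounds, whether a carboxylic acid or a primary amine in place of tert-butyl would give a step beyond the scatter remains open. On these data alone, the opposite configuration at the defined stereocentre also remains open.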